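The compounds below may be only part of what the source reports. "The series", "measured", "known", "first", "only" and "open" are said of these compounds alone.

In a functional assay on MCF7 cells (Homo sapiens) for antiproliferative activity, read by CCK-8 assay, with a stated time of 48 h (on this read-out lower numbers stand for stronger inhibition and higher numbers for weaker inhibition), compound 3 `C=CC(=O)NCCOc1ccc(Oc2c(-c3ccc(F)cc3)sc3cc(O)ccc23)cc1` gives 23000 nM, the higher of the two exact numbers in this small set. Compound 1 `O=C(/C=C/CNCCOc1ccc(Oc2c(-c3ccc(F)cc3)sc3cc(O)ccc23)cc1)N1CCCC1` gives 7610 nM, and the comparison shows a 3.0-fold higher number from compound 1 to compound 3 (0.48 log units; beyond the scatter). Compound 2 `CNC(=O)/C=C/CN1CC(Oc2ccc(Oc3c(-c4ccc(F)cc4)sc4cc(O)ccc34)cc2)C1` reports only a limit, > 25000 nM. Its comparison, an at least 1.0-fold lower number from compound 2 to compound 3 (0.03 log units; that floor lies within the scatter), says little about size. Compound 4 `C=C(C)C(=O)NCCOc1ccc(Oc2c(-c3ccc(F)cc3)sc3cc(O)ccc23)cc1` carries one change, (methyl in place of hydrogen on a double-bonded chain carbon bound to a carbonyl carbon), turning vinylcarbonyl into (1-methylethenyl)carbonyl. The closest guide is a 3.0-fold higher number from compound 1 to compound 3 (0.48 log units; beyond the scatter), a modest step that swaps a much larger group on the same amine nitrogen. A single methyl is a smaller edit, so little movement is expected. The expected 1.2-fold lower number from compound 3 to compound 4 (0.06 log units; within the scatter) stays within the scatter. The estimate for compound 4 is 20000 nM, with an expected range from 10000 nM to 35000 nM.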

Compound 4, half-maximal inhibitory concentration: > 25000 nM
Compound 4: a limit, no number (the forecaster's own chance of this, stated with the estimate: 35%); at least 1.2-fold (0.09 log units) between middle value and limit.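

The methyl on the double-bonded chain carbon bound to the carbonyl carbon leaves compound 4 with a limit, not a number: the limit of > 25000 nM in this assay, at which 2 of the 4 values shown sit. The methyl gives an at least 1.0-fold higher number from compound 3 to compound 4 (0.03 log units; that floor lies within the scatter), so this change cannot be sized and the two compounds cannot be told apart. The swap on the amine nitrogen gives an at least 3.2-fold higher number from compound 1 to compound 4 (0.51 log units; beyond the scatter), so (1-methylethenyl)carbonyl, like vinylcarbonyl, gives a higher number than the longer group of compound 1, while the step involving compound 2 cannot be read.

Open, from the compounds shown here alone, is whether a larger group at this carbon, such as ethyl or an aminomethyl chain, would give a readable number.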